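A few compounds are considered here, and "the series" means these few. Any claim that something is new, unique, unknown or untested is made for them only; others in the source may bear on it.

Compound 1 `COc1ccc(C(=O)Nc2ccc3ncc(-c4cnn(C)c4)cc3n2)cc1` gives 6400 nM in a functional assay on A549 cells (Homo sapiens) for antiproliferative activity, read by MTT assay, with a stated time of 48 h; on this read-out higher numbers stand for weaker inhibition and lower numbers for stronger inhibition. Compound 2 `Cn1cc(-c2cnc3ccc(NC(=O)c4cccnc4)nc3c2)cn1` is reported in this assay only as a limit, > 50000 nM. Compound 3 `COc1ccc(C(=O)Nc2nccc3ncc(-c4cnn(C)c4)cc23)cc1` is likewise reported in this assay only as a limit, > 50000 nM.

The one counted step among these three is an at least 7.8-fold higher number from compound 1 to compound 2 (0.89 log units; beyond the scatter), the change being (pyridin-3-yl in place of 4-methoxyphenyl on a carbonyl carbon). Compound 3 has the same atoms as compound 1 joined differently, and the difference between the two cores is not broken down here. Compound 4 `Cn1cc(-c2cnc3ccnc(NC(=O)c4cccnc4)c3c2)cn1` has not yet been measured in this assay; it carries the same change made on compound 3, namely (pyridin-3-yl in place of 4-methoxyphenyl on a carbonyl carbon), and the place is described in the same words for both pairs. The number for compound 3 already sits at the limit of > 50000 nM in this assay, at which 2 of the 3 values shown sit. As the same change carried compound 1 to compound 2 beyond that limit, compound 4 is expected to remain at the limit as well. The step from compound 3 to compound 4 is estimated as a step that the limit leaves unreadable from compound 3 to compound 4. For compound 4 the expected value in this assay is 100000 nM, within 50000 nM and 400000 nM.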

Compound 4, half-maximal inhibitory concentration: > 50000 nM
Compound 4 gave a limit, no number; the forecaster's own chance of this, stated with the estimate: 90%; the middle value is on the limit's open side.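

In this assay compound 4 gives > 50000 nM, which is a limit and not a number. Compound 3 is also reported only as a limit, so no step from compound 3 to compound 4 can be read, and compound 4 joins the others there: the limit of > 50000 nM in this assay, at which 3 of the 4 values shown sit.

The compounds shown leave open what pyridin-3-yl in place of 4-methoxyphenyl does on the core of compound 3.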